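The source may hold more compounds than are shown below. What is called first, only, known or untested is meant among the compounds shown, and "the series" means these compounds.

Two compounds carry the shared core of compound 1 `C#CCN(c1nc2ccc(F)cc2s1)c1nc2ccc(OC)cc2s1` with different groups on the central nitrogen. In a functional assay on COLO 205 cells (Homo sapiens) for antiproliferative activity, read by MTT assay (on this read-out higher numbers stand for weaker inhibition and lower numbers for stronger inhibition), compound 1 gives 30300 nM. Compound 2 `COc1ccc2nc(N(Cc3cc(-c4ccc(OC(F)(F)F)cc4)no3)c3nc4ccc(F)cc4s3)sc2c1` has the lower of the two numbers: in this assay compound 2 gives 9940 nM, with compound 1 standing a good deal higher and beyond the usual scatter.

Compound 3 `COc1ccc2nc(N(Cc3cc(-c4cc(OC)c(OC)c(OC)c4)no3)c3nc4ccc(F)cc4s3)sc2c1` is compound 2 with one change: 3,4,5-trimethoxyphenyl in place of 4-(trifluoromethoxy)phenyl on an aromatic carbon. Among the compounds with values here, no step between measured compounds bears on this exchange, so the direction of the step can only be guessed from the two values in hand. A modest change is expected, from compound 2 to compound 3 of about a 1.4-fold lower number from compound 2 to compound 3 (0.15 log units; within the scatter), as likely to fall within the scatter as to go slightly either way. Compound 3 is therefore estimated in this assay at 7000 nM, with a range from 2000 nM to 25000 nM.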

Compound 3, half-maximal inhibitory concentration: 11800 nM
The estimate for compound 3 lay 1.7-fold (0.23 log units) below the measured number, within the range that was stated.
By their numbers in this assay, from the lowest: compounds 2 and 3 (each within the scatter of the next); then compound 1.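

In this assay, the exchange of 4-(trifluoromethoxy)phenyl for 3,4,5-trimethoxyphenyl on this aromatic carbon gives a 1.2-fold higher number from compound 2 to compound 3 (0.07 log units; within the scatter) and so stays within the scatter. Within the data shown here, this is the first direct reading at this position, and it shows that these two aryl groups are not told apart here, although the entering group carries three methoxy groups and more hydrogen-bond acceptors than the group it replaces. Nothing at hand explains why the two groups read alike.

Going by these compounds, whether any group at this carbon can move the number beyond the scatter stays open, since both groups compared are substituted phenyl rings. An amine or a carboxylic acid on that phenyl ring, or a short alkyl chain in its place, might read differently, and the compounds shown cannot say.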